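Bicyclic Amine Added to a Weak Receptor Binder

A few compounds are considered here, and "the series" means these few. Any claim that something is new, unique, unknown or untested is made for them only; others in the source may bear on it.

Compound 1 `CCCC(=O)Nc1ccc(-c2cn3c(=O)c(C(=O)OC(CC)CC)cn(Cc4ccccc4F)c3n2)cc1` was tested in an assay on isolated protein for agonist activity at Gonadotropin-releasing hormone receptor (Homo sapiens) (on this read-out lower numbers stand for stronger inhibition and higher numbers for weaker inhibition), and gives 28000 nM, the higher of the two numbers at hand. Compound 2 `CCOC(=O)c1cn(Cc2ccccc2F)c2nc(-c3ccc(OC)cc3)c(CN(C)Cc3ccccc3)n2c1=O` shares the fused core but carries different groups on it, and in this assay compound 2 gives 950 nM, a gap from compound 1 that is beyond the usual scatter. Compound 3 `CCCC(=O)Nc1ccc(-c2nc3n(Cc4ccccc4F)cc(C(=O)OC(CC)CC)c(=O)n3c2N2CCC3C=CC=CC3C2)cc1` is not yet measured. It differs from compound 1 in one place: a group of 10 heavy atoms (9 carbon, 1 nitrogen; one six-membered non-aromatic ring of carbon only, one six-membered non-aromatic ring with 1 hetero atom) in place of a hydrogen atom, on an aromatic carbon. For the measured compounds named here, no measured pair shows this exact change, so the expectation rests on the comparison at hand: an improvement is expected because compound 2, which carries an added group on the same core, gives 950 nM. The step from compound 1 to compound 3 is estimated as a move toward stronger binding, a 19-fold lower number from compound 1 to compound 3 (1.27 log units; beyond the scatter), larger than the scatter. For compound 3 the estimate in this assay is 1500 nM, within a range from 200 nM to 10000 nM.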

Compound 3, inhibition constant: 290 nM
Compound 3: middle estimate off by 5.2-fold (0.71 log units), on the high side; low and high end bracket the measured number.
By their numbers in this assay, from the lowest: compound 3; then compound 2; then compound 1.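

In this assay, for the compounds shown here, replacing one hydrogen atom on the aromatic carbon of the five-membered ring with the two-ring amine group gives a 97-fold lower number from compound 1 to compound 3 (1.98 log units; beyond the scatter), the only change between these two compounds. The earlier pair differed in several places and could not tie a change in binding to this carbon, whereas this step shows that the position accepts a group of 10 heavy atoms and that binding becomes much stronger with it there. No measurement at hand explains the gain.

On these data alone, it remains open whether both rings and their two double bonds are needed, which a simple piperidine or the fully saturated two-ring amine at this carbon would test. A dimethylamino group there would ask whether a much smaller amine is enough.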